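Cyclopropyl in Place of Ethyl on the Shared Core

The source may report more compounds than this note shows. Statements on the series, on what has been measured and on what is new or still open speak of the compounds shown alone.

Of the compounds shown here, three built on one shared core have been measured in a functional assay on PC-3 cells (Homo sapiens) for cytotoxicity, read by MTT assay, with a stated time of 48 h; on this read-out higher numbers stand for weaker inhibition and lower numbers for stronger inhibition. Compound 1 `[O-][n+]1nc(NCc2ccccc2Cl)[n+]([O-])c2ccccc21` gives 10600 nM, compound 2 `[O-][n+]1nc(NCCO)[n+]([O-])c2ccccc21` gives 22400 nM, and compound 3 `CCNc1n[n+]([O-])c2ccccc2[n+]1[O-]` gives 13300 nM. Compound 3 stands second highest of the three numbers: the step of a 1.3-fold higher number from compound 1 to compound 3 (0.10 log units; within the scatter) is within the scatter, as is a 1.7-fold lower number from compound 2 to compound 3 (0.23 log units; within the scatter), and only a 2.1-fold higher number from compound 1 to compound 2 (0.32 log units; beyond the scatter) goes beyond it, and then modestly.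

Compound 4 `[O-][n+]1nc(NC2CC2)[n+]([O-])c2ccccc21` differs from compound 3 in one place: cyclopropyl in place of ethyl on a nitrogen on an aromatic ring. Among the compounds with values here, no measured step involves a cyclopropyl. The three steps that alter the group on the same nitrogen, a 2.1-fold higher number from compound 1 to compound 2 (0.32 log units; beyond the scatter), a 1.3-fold higher number from compound 1 to compound 3 (0.10 log units; within the scatter) and a 1.7-fold lower number from compound 2 to compound 3 (0.23 log units; within the scatter), move the number little, even when a 2-chlorophenyl is exchanged for a methyl or a hydroxymethyl. A step from ethyl to cyclopropyl is therefore expected to stay within the scatter in this assay, with no clear direction. Compound 4 is estimated at 12000 nM, within a range from 5000 nM to 30000 nM, which corresponds to an expected step of a 1.1-fold lower number from compound 3 to compound 4 (0.04 log units; within the scatter).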

Compound 4, half-maximal inhibitory concentration: 15900 nM
Compound 4: middle estimate off by 1.3-fold (0.12 log units), on the low side; measured number inside the range.
By their numbers in this assay, from the lowest: compounds 1, 3, 4 and 2 (each within the scatter of the next, the first and the last beyond it).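

In this assay, cyclopropyl in place of ethyl on a nitrogen on an aromatic ring gives a 1.2-fold higher number from compound 3 to compound 4 (0.08 log units; within the scatter) and so brings the first three-membered ring into the series without a step beyond the scatter. Set against the 2-hydroxyethyl group, the same cyclopropyl gives a 1.4-fold lower number from compound 2 to compound 4 (0.15 log units; within the scatter) and again stays within the scatter. On this read-out, then, the cyclopropyl group at this position cannot be told apart from either the ethyl or the 2-hydroxyethyl chain.

As far as these compounds go, it remains open whether a larger ring such as cyclohexyl, a longer chain, or a chain ending in an amine or a carboxylic acid would move the number beyond the scatter. Nothing shown here bears on why this change leaves the number within the scatter.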